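Working notes: sulfanyl variation, estimate for compound 4

This account rests on a few compounds, and the source may have more. Where it says the series, first, only, none or still open, it means among the compounds named here.

The series shares one core and varies the ring carried on a sulfur whose other neighbour is a saturated chain carbon. Within the data shown here, compound 1 `O=C(CSc1nnnn1-c1ccccc1)N/N=c1/scc(-c2ccc(Br)cc2)n1-c1ccccc1` is the only member with a number: in a functional assay on C6 cells (Rattus norvegicus) for cytotoxicity, read by MTT assay, with a stated time of 24 h (a lower number here means a stronger inhibitor, a higher number a weaker inhibitor), compound 1 gives 21 ug/mL. Compound 2 `Cn1nnnc1SCC(=O)N/N=c1/scc(-c2ccc(Br)cc2)n1-c1ccccc1` has no result in this assay, entered as "not determined" (no result reported). Compound 3 `Cn1cnnc1SCC(=O)N/N=c1/scc(-c2ccc(Br)cc2)n1-c1ccccc1` likewise has no result; in this assay compound 3 stands at "not determined" (no result reported), so nothing places it relative to compound 1, and compound 2 is a second entry without a number. Compound 4 `O=C(CSc1ncccn1)N/N=c1/scc(-c2ccc(Br)cc2)n1-c1ccccc1` is not yet measured. The change from compound 3 to compound 4 is pyrimidin-2-yl in place of 4-methyl-4H-1,2,4-triazol-3-yl on a sulfur. Among the measured compounds shown here, no measured pair shows what such an exchange does in this assay, and with compound 3 itself unmeasured there is no anchor for a step of any size or direction. For the measured compounds named here, the only guide is compound 1, whose value in this assay is 21 ug/mL; the expectation is therefore a value of the same order for compound 4, with no direction favoured and a wide range. Compound 4 is estimated at 25 ug/mL in this assay, expected to fall between 8 ug/mL and 80 ug/mL.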

Compound 4, half-maximal inhibitory concentration: > 200 ug/mL
Compound 4 gave a limit, no number; the forecaster's own chance of this, stated with the estimate: 20%; middle value at least 8.0-fold (0.90 log units) from the limit.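

In this assay, compound 4 gives a limit of the assay and not a number: the limit of > 200 ug/mL in this assay, at which 1 of the 4 values shown sits.

With the rest of the structure unchanged, pyrimidin-2-yl in place of 1-phenyl-1H-tetrazol-5-yl on a sulfur gives an at least 9.5-fold higher number from compound 1 to compound 4 (0.97 log units; beyond the scatter). Among these compounds, this is the first measured step, and it shows that the number at this position depends on the ring carried on the sulfur, with the pyrimidin-2-yl compound on the weaker side. The steps involving compound 2 and compound 3 cannot be read, as neither has a result, so the exchange of 4-methyl-4H-1,2,4-triazol-3-yl for pyrimidin-2-yl still has no measured size or direction.

From the compounds shown here alone, one step resting on a limit does not tell whether the difference follows the phenyl on the tetrazole or the change of ring itself, and its full size stays unknown. Also open, going by these compounds, is how a non-ring group on the sulfur, such as a dimethylamino group or a carboxylic acid on a longer chain, would read in this assay against compound 1 at 21 ug/mL.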